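Swapping the Chain-End Amine on a Quinazoline Scaffold

The source may report more compounds than this note shows. Statements on the series, on what has been measured and on what is new or still open speak of the compounds shown alone.

Compound 2, `CCOC(=O)C1CCN(CCCOc2cc3ncnc(Nc4ccc(C#N)cc4)c3cc2OC)CC1`, is one of two compounds that share a core and differ only in the amine at the end of a three-carbon chain. In a functional assay on SH-SY5Y cells (Homo sapiens) for antiproliferative activity, read by MTT assay, with a stated time of 72 h (on this read-out higher numbers stand for weaker inhibition and lower numbers for stronger inhibition), compound 2 gives 47200 nM, the only number shown for this series. Compound 1, `CCN(CC)CCCOc1cc2ncnc(Nc3ccc(C#N)cc3)c2cc1OC`, reaches only a limit, (the limit of > 100000 nM in this assay, at which 1 of the 2 values shown sits), so its value of > 100000 nM is a limit and not a number. Among the measured compounds shown here, the single measured step is an at least 2.1-fold lower number from compound 1 to compound 2 (0.32 log units; beyond the scatter); it shows that changing the amine at this place can move the number beyond the scatter.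

Compound 3, `COc1cc2c(Nc3ccc(C#N)cc3)ncnc2cc1OCCCN1CCc2ccccc2C1`, is not yet measured. It differs from compound 2 by 1,2,3,4-tetrahydroisoquinolin-2-yl in place of 4-(ethoxycarbonyl)piperidin-1-yl on a saturated chain carbon, three bonds along the chain from an oxygen on an aromatic ring. For the measured compounds named here, this change again touches only the chain-end amine, so the measured step from compound 1 to compound 2 is the only guide, and it points to a modest move at most. A small improvement is expected, a 1.6-fold lower number from compound 2 to compound 3 (0.20 log units; within the scatter), but within a wide range. In this assay compound 3 is estimated at 30000 nM, with a range from 8000 nM to 100000 nM.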

Compound 3, half-maximal inhibitory concentration: > 100000 nM
Compound 3 was reported as a limit (the forecaster's own chance of this, stated with the estimate: 20%); middle value at least 3.3-fold (0.52 log units) from the limit.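

In this assay the new step is an at least 2.1-fold higher number from compound 2 to compound 3 (0.32 log units; beyond the scatter), so changing the chain-end amine can push the number up as well as down, and the direction depends on which amine enters. Of the three chain-end amines shown, only 4-(ethoxycarbonyl)piperidin-1-yl gives a number, and the 1,2,3,4-tetrahydroisoquinolin-2-yl that replaces it, despite bringing an aromatic ring of carbon only, does not keep that number. The step from compound 1 to compound 3 cannot be read, since both values are limits, and most of this small series now sits at that same limit: the limit of > 100000 nM in this assay, at which 2 of the 3 values shown sit.

The compounds shown leave open which part of 4-(ethoxycarbonyl)piperidin-1-yl goes with the measurable number, the ethyl ester or the saturated ring that carries it. A carboxylic acid in place of the ethyl ester, a plain piperidin-1-yl or a longer chain to the same amine could help separate these parts, but none of them is among the compounds here.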